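Methyl Substitution on the Core of Compound 1

The source may report more compounds than this note shows. Statements on the series, on what has been measured and on what is new or still open speak of the compounds shown alone.

Measured so far:
Compound 1, `COC(=O)N[C@H]1Cc2ccc(NC(=O)c3ccccc3-c3ccc(C(F)(F)F)cc3)cc2C1`, in an assay for inhibition of apolipoprotein B-100 (Homo sapiens), tested at 100 nM (a higher number here means a weaker inhibitor, a lower number a stronger inhibitor), gives 1.9 nM.
Compound 2, `COC(=O)N[C@@H]1Cc2ccc(NC(=O)c3ccccc3-c3ccc(C(F)(F)F)cc3)cc2C1`, in this assay gives 5.2 nM.

Compound 1 stands lowest of the two numbers. Its nearest neighbour is compound 2, and the step of a 2.7-fold higher number from compound 1 to compound 2 (0.44 log units; beyond the scatter) is modest but beyond the scatter. That step rests on the fact that compounds 1 and 2 differ only in the configuration as drawn and nothing else, since the two compounds share every atom and bond.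

Compound 3, `COC(=O)N[C@H]1Cc2ccc(NC(=O)c3cc(C)ccc3-c3ccc(C(F)(F)F)cc3)cc2C1`, has not yet been measured. It differs from compound 1 by methyl in place of hydrogen on an aromatic carbon. Within the data shown here, no measured step changes a ring substituent in this way: the only step available, between compound 1 and compound 2, concerns a stereocentre and does not bear on an added methyl. The expected step of a 1.1-fold lower number from compound 1 to compound 3 (0.02 log units; within the scatter) is therefore small, lying within the scatter in either direction. Compound 3 is estimated at 1.8 nM, with a range from 0.6 nM to 5.5 nM.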

Compound 3, half-maximal inhibitory concentration: 2.2 nM
The estimate for compound 3 lay 1.2-fold (0.09 log units) below the measured number; low and high end bracket the measured number.
By their numbers in this assay, from the lowest: compounds 1 and 3 (each within the scatter of the next); then compound 2.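

In this assay, methyl in place of hydrogen on this aromatic carbon, meta to a large group and para to a 4-(trifluoromethyl)phenyl group, gives a 1.2-fold higher number from compound 1 to compound 3 (0.06 log units; within the scatter) and so leaves the number where it was within the scatter. Among these compounds, the one earlier step concerned only the stereocentre, so this is the first reading on a substituent at this ring, and it shows that the position accepts a methyl with no measurable loss in this assay. Nothing available bears on why the methyl leaves the number unmoved.

As far as these compounds go, whether ethyl, methoxy, an amine or a carboxylic acid on this same carbon would also leave the number unmoved remains open. So does whether a methyl on the other carbons of this ring, or on the core of compound 2, would behave in the same way.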